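The source may hold more compounds than are shown below. What is called first, only, known or untested is meant among the compounds shown, and "the series" means these compounds.

Compound 1 `CC(C)n1cc(S(=O)(=O)c2ccc(CNC(=O)N3Cc4ccncc4C3)cc2)cn1` was tested in a physicochemical assay for solubility, in phosphate buffer, with a stated time of 24 h, at pH 7.4, tested at 100 uM (on this read-out higher numbers stand for higher solubility and lower numbers for lower solubility), and in that test compound 1 gives 192000 nM. Compound 2 `CC(=O)N1CCC(S(=O)(=O)c2ccc(CNC(=O)N3Cc4ccncc4C3)cc2)CC1` gives 187000 nM, and compound 3 `O=C(NCc1ccc(S(=O)(=O)N2CCOCC2)cc1)N1Cc2ccncc2C1` gives 59000 nM. On these three numbers compound 1 sits at the top end: the gap to compound 2 is a 1.0-fold lower number from compound 1 to compound 2 (0.01 log units; within the scatter), while the gap to compound 3 is a 3.3-fold lower number from compound 1 to compound 3 (0.51 log units; beyond the scatter).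

Compound 4 `O=C(NCc1ccc(S(=O)(=O)N2CC3(CCOCC3)C2)cc1)N1Cc2ccncc2C1` has not yet been measured. It differs from compound 1 in one place: a group of 9 heavy atoms (7 carbon, 1 nitrogen, 1 oxygen; one four-membered non-aromatic ring with 1 hetero atom, one six-membered non-aromatic ring with 1 hetero atom) in place of a group of 8 heavy atoms (6 carbon, 2 nitrogen; one five-membered aromatic ring with 2 hetero atoms), on a sulfonyl sulfur. The measured step that bears most closely on this is the one in which a non-aromatic ring joined through nitrogen replaces the same aromatic group on the sulfonyl sulfur, a 3.3-fold lower number from compound 1 to compound 3 (0.51 log units; beyond the scatter); the corresponding swap from compound 2 gave a 3.2-fold lower number from compound 2 to compound 3 (0.50 log units; beyond the scatter). Since the entering group in compound 4 is again a non-aromatic ring joined to the sulfonyl sulfur through nitrogen, a downward step of about that order is expected, a 3.8-fold lower number from compound 1 to compound 4 (0.58 log units; beyond the scatter). Compound 4 is therefore estimated at 50000 nM in this assay, within a range of 20000 nM to 120000 nM.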

Compound 4, solubility: 272000 nM
Compound 4: middle estimate off by 5.4-fold (0.74 log units), on the low side; the whole stated range lies below it.
By their numbers in this assay, from the lowest: compound 3; then compounds 2, 1 and 4 (each within the scatter of the next).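

On a sulfonyl sulfur, a non-aromatic ring joined through nitrogen does not by itself go with the number of compound 3: the group with a four-membered and a six-membered non-aromatic ring gives a 4.6-fold higher number from compound 3 to compound 4 (0.66 log units; beyond the scatter). The same group cannot be told apart from the two earlier groups, with a 1.4-fold higher number from compound 1 to compound 4 (0.15 log units; within the scatter) and a 1.5-fold higher number from compound 2 to compound 4 (0.16 log units; within the scatter), so in this assay only compound 3 stands apart among the four compounds. Nothing available accounts for this separation.

The compounds shown leave open whether a plain azetidin-1-yl or piperidin-1-yl on the sulfonyl sulfur would fall with compound 3 or with compound 4. They also leave open which of the two rings in the group of compound 4 goes with its separation from compound 3.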